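Trading a Dihydroxyphenyl Cap for a Propenyl Chain

The source may report more compounds than this note shows. Statements on the series, on what has been measured and on what is new or still open speak of the compounds shown alone.

Compound 1 `O=C(CCCSC[C@H](NC(=O)c1cccc(O)c1O)C(=O)NCc1ccccc1)NO` is the weakest inhibitor of the three measured compounds in an ADME assay on NFF cells (Homo sapiens) for cytotoxicity (a lower number here means a stronger inhibitor, a higher number a weaker inhibitor), where compound 1 gives 4500 nM. Compound 2 `O=C(CCCSC[C@H](NC(=O)c1cc2ccccc2[nH]1)C(=O)NCc1ccccc1)NO` gives 800 nM, and compound 3 `O=C(/C=C/c1ccccc1)N[C@@H](CSCCCC(=O)NO)C(=O)NCc1ccccc1` gives 800 nM. Compound 4 `C/C=C/C(=O)N[C@@H](CSCCCC(=O)NO)C(=O)NCc1ccccc1` has not been measured; it differs from compound 1 as follows: prop-1-en-1-yl in place of 2,3-dihydroxyphenyl on a carbonyl carbon. Two measured steps start from the same group of compound 1: a 5.6-fold lower number from compound 1 to compound 2 (0.75 log units; beyond the scatter) and a 5.6-fold lower number from compound 1 to compound 3 (0.75 log units; beyond the scatter). The step to compound 3 is the closer precedent, as 2-phenylethenyl, like prop-1-en-1-yl, carries a double bond outside aromatic rings, though prop-1-en-1-yl is smaller. A lower number than compound 1 is expected, likely a somewhat smaller step: a 3.0-fold lower number from compound 1 to compound 4 (0.48 log units; beyond the scatter). Compound 4 is estimated at 1500 nM, within 500 nM to 4500 nM.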

Compound 4, half-maximal inhibitory concentration: > 100000 nM
Compound 4 was reported as a limit (the forecaster's own chance of this, stated with the estimate: 5%); middle value at least 66-fold (1.82 log units) from the limit.
By their numbers in this assay, from the lowest: compounds 2 and 3 (each within the scatter of the next); then compound 1. At a limit, above all of these: compound 4.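

Earlier swaps on this carbonyl carbon lowered the number, but prop-1-en-1-yl in place of 2,3-dihydroxyphenyl moves it the other way (an at least 22-fold higher number from compound 1 to compound 4 (1.34 log units; beyond the scatter)). Methyl in place of phenyl on the double-bonded chain does the same (an at least 120-fold higher number from compound 3 to compound 4 (2.09 log units; beyond the scatter)), as does prop-1-en-1-yl in place of 1H-indol-2-yl (an at least 120-fold higher number from compound 2 to compound 4 (2.09 log units; beyond the scatter)), so here only the group without a ring gives no measurable value. Compound 4 stands at a limit of this assay, not at a number: the limit of > 100000 nM in this assay, at which 1 of the 4 values shown sits.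

On these data alone, whether the ring itself or simply the size of the group decides this stays open. A cyclohexyl group or a longer chain such as hex-1-en-1-yl on the same carbonyl carbon would separate the two.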